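Replacing an ethynyl arm with a bromopropyl carbamoyl arm

The source may hold more compounds than are shown below. What is called first, only, known or untested is meant among the compounds shown, and "the series" means these compounds.

Three measured compounds share one core and differ only in the group on the saturated chain carbon bound to an oxygen on an unsaturated carbon. In a functional assay on MCF7 cells (Homo sapiens) for inhibition, read by radiometric assay and XTT assay (on this read-out higher numbers stand for weaker inhibition and lower numbers for stronger inhibition), compound 1 `CCCCCC[C@@]1(C)SC(=O)C=C1OC` gives 9.4 ug/mL, compound 2 `CCCCCC[C@@]1(C)SC(=O)C=C1OCCCCCl` gives 20.8 ug/mL, and compound 3 `C#CCOC1=CC(=O)S[C@]1(C)CCCCCC` gives 8.9 ug/mL. The number for compound 3 is the smallest shown, but its difference from compound 1 lies within the scatter, so only compound 2 is clearly separated from it. Compound 4 `CCCCCC[C@@]1(C)SC(=O)C=C1OCC(=O)NCCCBr` is not yet measured; the change is (3-bromopropyl)carbamoyl in place of ethynyl on a saturated chain carbon bound to an oxygen on an unsaturated carbon. Among the measured compounds shown here, two steps bear on it: a 2.2-fold higher number from compound 1 to compound 2 (0.34 log units; beyond the scatter) and a 2.3-fold lower number from compound 2 to compound 3 (0.37 log units; beyond the scatter), both showing a modestly higher number for a longer arm at this place. A modest rise is therefore expected, a 1.8-fold higher number from compound 3 to compound 4 (0.25 log units; within the scatter). Compound 4 is thus estimated at 16 ug/mL, with a range of 7 ug/mL to 35 ug/mL.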

Compound 4, half-maximal inhibitory concentration: 21 ug/mL
Beside the measured number, compound 4's estimate is 1.3-fold (0.12 log units) below it; measured number inside the range.
By their numbers in this assay, from the lowest: compounds 3 and 1 (each within the scatter of the next); then compounds 2 and 4 (each within the scatter of the next).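

In this assay the (3-bromopropyl)carbamoyl arm gives a 2.4-fold higher number from compound 3 to compound 4 (0.37 log units; beyond the scatter) and a 2.2-fold higher number from compound 1 to compound 4 (0.35 log units; beyond the scatter), yet it gives only a 1.0-fold higher number from compound 2 to compound 4 (0.00 log units; within the scatter), so this place tolerates a much larger arm, one holding an amide hydrogen, with no further change from the 3-chloropropyl arm. Arm size alone does not set the number, since the ethynyl arm of compound 3 also differs from compound 1 but stays within the scatter of it. Nothing shown explains this behaviour. From the compounds shown here alone, whether the bromine or the carbamoyl matters more stays open, as does the effect of a carboxylic acid, an amine or a longer chain at this place.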